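Fluoroaryl Ether Swap on a Benzoxindole Core

This account rests on a few compounds, and the source may have more. Where it says the series, first, only, none or still open, it means among the compounds named here.

Compounds measured so far:
Compound 1, `CC(C)c1ccc(OCCOc2ccc3[nH]c(=O)n(C(C)C)c3c2)cc1`: 14.1%
Compound 2, `CC(C)=C1C(=O)Nc2ccc(OCc3cccc(C)c3)cc21`: "not active" (no number reported)
Compound 3, `Cn1c(=O)[nH]c2ccc(OCCOc3ccc(Cl)cc3)cc21`: 9.94%

In an assay on cells for inhibition of Amine oxidase [flavin-containing] B (Homo sapiens), read by fluorescence, with stated times of 30 min and 15 min, tested at 1 uM (a lower number here means less inhibition, a higher number more inhibition at the concentration tested (going by the name of the read-out)), compound 1 gives 14.1% and compound 3 gives 9.94%; these two values lie within the usual scatter of each other, so no order between them can be claimed. Compound 2 stands apart in that it is reported only as "not active" (no number reported), without a number, so its place relative to compounds 1 and 3 cannot be fixed on the figures shown.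

Compound 4, `CC(C)=C1C(=O)Nc2ccc(OCc3ccc(F)cc3)cc21`, has not yet been measured. It differs from compound 2 in one place: 4-fluorophenyl in place of 3-methylphenyl on a saturated chain carbon bound to an oxygen on an aromatic ring. Among the measured compounds shown here, no measured pair in this set shows a change of this kind, so nothing here tells how large its effect should be. Given that compound 2 shows no reportable inhibition, the step in this assay is expected to stay within the scatter, with no clear direction. Compound 4 is therefore estimated at 8%, with a range from -5% to 25%.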

Compound 4, a percentage reported as inhibition, at one concentration (the size of the read-out at that concentration, not a potency): "not active" (no number reported)
Nothing numeric was reported for compound 4; no gap can be computed for the estimate.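

Compound 2 and compound 4 are both reported in this assay only as "not active", without a number, and no step can be read between them. No evidence at hand bears on this result. The compounds shown leave open whether 4-fluorophenyl in place of 3-methylphenyl alters inhibition at all.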